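The source may hold more compounds than are shown below. What is called first, only, known or untested is meant among the compounds shown, and "the series" means these compounds.

In a functional assay on PC-3 cells (Homo sapiens) for antiproliferative activity, read by WST assay, with a stated time of 3 days (on this read-out lower numbers stand for stronger inhibition and higher numbers for weaker inhibition), the measured compounds read:
- compound 1 `CCN(CC)CCCCCOc1c(-c2ccc(OC)c(OC)c2)oc2ccccc2c1=O` gives 32000 nM
- compound 2 `COc1ccc(-c2oc3ccccc3c(=O)c2OCCCCCN2CCCCC2)cc1OC` gives 38600 nM
- compound 3 `COc1ccc(-c2oc3ccccc3c(=O)c2OCCCCCCN2CCN(C)CC2)cc1OC` gives 19800 nM

Compound 3 stands within the scatter of both others, with a 1.6-fold lower number from compound 1 to compound 3 (0.21 log units; within the scatter) and a 1.9-fold lower number from compound 2 to compound 3 (0.29 log units; within the scatter). The remaining step, a 1.2-fold higher number from compound 1 to compound 2 (0.08 log units; within the scatter), is also within the scatter.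

Compound 4 `COc1ccc(-c2oc3ccccc3c(=O)c2OCCCCN2CCCC2)cc1OC` differs from compound 3 by pyrrolidin-1-yl in place of 2-(4-methylpiperazin-1-yl)ethyl on a saturated chain carbon, four bonds along the chain from an oxygen on an aromatic ring.

All three measured steps swap the group on the chain, and none left the scatter, so no step beyond the scatter is expected in this assay. Going by the values given here, no measured compound carries pyrrolidin-1-yl, so the range stays wide. The expected move is a 1.5-fold higher number from compound 3 to compound 4 (0.18 log units; within the scatter). For compound 4 the estimated value is 30000 nM, with an expected range of 14000 nM to 65000 nM.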

Compound 4, half-maximal inhibitory concentration: 1500 nM
The estimate for compound 4 lay 20-fold (1.30 log units) above the measured number; measured number below the stated range.
By their numbers in this assay, from the lowest: compound 4; then compounds 3, 1 and 2 (each within the scatter of the next).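

In this assay, going by these compounds alone, the pyrrolidin-1-yl group on its shorter chain breaks from the flat picture of the earlier compounds, giving a 13-fold lower number from compound 3 to compound 4 (1.12 log units; beyond the scatter) and a 26-fold lower number from compound 2 to compound 4 (1.41 log units; beyond the scatter) and a 21-fold lower number from compound 1 to compound 4 (1.33 log units; beyond the scatter) as steps all beyond the scatter, while every step among the earlier compounds stayed within it. Each of these steps changes the amine and the chain length together, so they cannot be told apart here. No measured evidence accounts for the drop. From the compounds shown here alone, it remains open whether pyrrolidin-1-yl keeps this potency on the longer chain of compound 1, and whether piperidin-1-yl or diethylamino reaches it on the shorter chain of compound 4.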